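The source may report more compounds than this note shows. Statements on the series, on what has been measured and on what is new or still open speak of the compounds shown alone.

Compound 3 `Cc1cccc(COc2ccc(-c3nn(CCC#N)c(=S)o3)cc2)c1` gives 66 nM in an assay for inhibition of Amine oxidase [flavin-containing] B (Rattus norvegicus) (on this read-out higher numbers stand for weaker inhibition and lower numbers for stronger inhibition), the highest of the three numbers on record. Compound 1 `N#CCCn1nc(-c2ccc(OCc3ccccc3)cc2)oc1=O` gives 2.2 nM in this assay, and compound 2 `COc1ccc(COc2ccc(-c3nn(CCC#N)c(=O)o3)cc2)cc1` gives 27 nM; compound 3 therefore sits furthest from compound 1 and nearest to compound 2, and both gaps lie beyond the scatter.

Compound 4 `N#CCCn1nc(-c2ccc(OCc3ccc(Cl)cc3)cc2)oc1=S` is not yet measured. The change from compound 3 is 4-chlorophenyl in place of 3-methylphenyl on a saturated chain carbon bound to an oxygen on an aromatic ring. Among the measured compounds shown here, only one measured step touches this benzyl ring: a 12-fold higher number from compound 1 to compound 2 (1.09 log units; beyond the scatter). For the measured compounds named here, that step shows a substituent on this ring can move the number by a large amount, but it swaps hydrogen for methoxy and does not cover a methyl-to-chlorine exchange, so no measured step bears directly on the change to compound 4. Compound 3 and compound 2 differ in two places, so their values can only be read side by side.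

Going by the values given here, with no direct precedent, compound 4 is expected to stay close to compound 3, a step of a 1.5-fold lower number from compound 3 to compound 4 (0.17 log units; within the scatter), and its estimate is 45 nM, within 8 nM to 250 nM.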

Compound 4, half-maximal inhibitory concentration: 690 nM
The estimate for compound 4 lay 15-fold (1.19 log units) below the measured number; the whole stated range lies below it.
By their numbers in this assay, from the lowest: compound 1; then compound 2; then compound 3; then compound 4.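

In this assay, replacing 3-methylphenyl with 4-chlorophenyl on a saturated chain carbon bound to an oxygen on an aromatic ring gives a 10-fold higher number from compound 3 to compound 4 (1.02 log units; beyond the scatter). This position therefore responds strongly not only to the hydrogen-to-methoxy change, a 12-fold higher number from compound 1 to compound 2 (1.09 log units; beyond the scatter), but also to an exchange between two substituted rings with the same count of heavy atoms. No measurement offered here accounts for the size of this step.

As far as these compounds go, the step changes both the substituent and its printed ring position at once, so it remains open whether the higher number follows the chlorine or its location, a question that a 3-chlorobenzyl or a 4-methylbenzyl group on the same core could separate. From the compounds shown here alone, it also remains open how a fluorine or an amine on this ring would read in this assay.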